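Pyridin-3-yl Replaces 4-Cyanophenyl on the Shared Core

The source may report more compounds than this note shows. Statements on the series, on what has been measured and on what is new or still open speak of the compounds shown alone.

For the measured compounds named here, compound 1 `Cc1cc(N2CCN([C@@H]3CN[C@H](C(=O)N4CCSC4)C3)CC2)n(-c2cccc(F)c2)n1` is the one member of this series with a number in a functional assay on the whole organism (plasma, strain Wistar) for inhibition, with Rattus norvegicus as the target, read by fluorescence, with a stated time of 9 h, at a dose of 3 umol/kg by the oral route; a higher number here means more inhibition at the dose given (going by the name of the read-out), a lower number less inhibition: compound 1 gives 75.1%. Compound 2 `Cc1cc(N2CCN([C@@H]3CN[C@H](C(=O)N4CCSC4)C3)CC2)n(-c2ccc(Cl)cc2)n1` was run in this assay, where compound 2 is reported as "not determined" (no result reported). Compound 3 `Cc1cc(N2CCN([C@@H]3CN[C@H](C(=O)N4CCSC4)C3)CC2)n(-c2ccc(C#N)cc2)n1` was likewise run in this assay, where compound 3 is reported as "not determined" (no result reported), so compound 3 stands without a number of its own, and a further entry in the set is likewise without one. Compound 4 `Cc1cc(N2CCN([C@@H]3CN[C@H](C(=O)N4CCSC4)C3)CC2)n(-c2cccnc2)n1` differs from compound 3 by a single change: pyridin-3-yl in place of 4-cyanophenyl on an aromatic nitrogen. Going by the values given here, no measured pair shows what such an exchange does in this assay, so the step from compound 3 to compound 4 cannot be read from the data; no change beyond the usual scatter is expected in either direction. Taking compound 1 as the only anchor, compound 4 is expected to reach about 65%, estimated between 30% and 90%.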

Compound 4, a percentage reported as inhibition, in the whole organism at one dose (the size of the read-out at that dose, not a potency): 40.8%
For compound 4 the middle estimate is 24.2 percentage points above the measured one; measured number inside the range.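

In this assay, for the compounds shown here, the exchange of 3-fluorophenyl for pyridin-3-yl on the aromatic nitrogen gives a number 34.3 percentage points lower from compound 1 to compound 4 (beyond the scatter), the first sign that the group at this position matters for inhibition at this dose. The step from compound 3 to compound 4 cannot be read, as compound 3 has no number. Nothing offered here accounts for the drop.

On these data alone, whether an unsubstituted phenyl or a pyridin-2-yl would stand closer to compound 1 or to compound 4 remains open. So does the effect of a methoxy group on the phenyl ring.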